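Chloro at the Same Place as Butyl and Tert-Butyl

The compounds below may be only part of what the source reports. "The series", "measured", "known", "first", "only" and "open" are said of these compounds alone.

Measured compounds:
compound 1, `NS(=O)(=O)NCC1CCN(c2cc(-c3ccccc3)ncn2)CC1` — 34300 nM
compound 2, `CCCCc1ccc(-c2cc(N3CCC(CNS(N)(=O)=O)CC3)ncn2)cc1` — 21800 nM
compound 3, `CC(C)(C)c1ccc(-c2cc(N3CCC(CNS(N)(=O)=O)CC3)ncn2)cc1` — 19700 nM

In a functional assay on MCF7 cells (Homo sapiens) for antiproliferative activity, read by sulforhodamine B assay, with a stated time of 48 h (on this read-out higher numbers stand for weaker inhibition of growth and lower numbers for stronger inhibition of growth), compound 1 gives 34300 nM. Compound 2 gives 21800 nM and compound 3 gives 19700 nM, and neither is separated from compound 1: the step of a 1.6-fold lower number from compound 1 to compound 2 (0.20 log units; within the scatter) and the step of a 1.7-fold lower number from compound 1 to compound 3 (0.24 log units; within the scatter) both stay within the scatter, as does a 1.1-fold lower number from compound 2 to compound 3 (0.04 log units; within the scatter). Compound 1 therefore stands alongside the other two rather than apart from them.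

Compound 4, `NS(=O)(=O)NCC1CCN(c2cc(-c3ccc(Cl)cc3)ncn2)CC1`, differs from compound 1 by chloro in place of hydrogen on an aromatic carbon. Among the compounds with values here, the steps that bear on this are those from compound 1 to compound 2 and from compound 1 to compound 3, where a butyl or a tert-butyl entered at the same aromatic carbon, both within the scatter. A chloro at that position is accordingly expected to move the number little, if anywhere slightly downward. Compound 4 is expected to give 28000 nM in this assay, with a range of 12000 nM to 60000 nM. That estimate means a step of a 1.2-fold lower number from compound 1 to compound 4 (0.09 log units; within the scatter), expected to remain within the scatter.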

Compound 4, concentration for 50% growth inhibition: 25500 nM
Compound 4: middle estimate off by 1.1-fold (0.04 log units), on the high side; the range from low to high includes it.
By their numbers in this assay, from the lowest: compounds 3, 2, 4 and 1 (each within the scatter of the next).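

Chloro on this aromatic carbon, para to a large group, adds a group of a single heavy atom to the butyl and tert-butyl already seen there, and its entry in place of hydrogen gives a 1.3-fold lower number from compound 1 to compound 4 (0.13 log units; within the scatter) in this assay and no separation from the parent. The new comparisons also leave the substituents themselves unseparated, with chloro in place of tert-butyl giving a 1.3-fold higher number from compound 3 to compound 4 (0.11 log units; within the scatter) and chloro in place of butyl giving a 1.2-fold higher number from compound 2 to compound 4 (0.07 log units; within the scatter) as well, so that neither hydrogen nor these three groups can be told apart at this carbon. No measurement shown accounts for this sameness of the four compounds.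

From the compounds shown here alone, whether an amine or a carboxylic acid at this carbon would give a step beyond the scatter remains open. So does whether chloro on another carbon of the same ring would read as it does here.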